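The source may hold more compounds than are shown below. What is called first, only, known or untested is meant among the compounds shown, and "the series" means these compounds.

In a functional assay on HCT-116 cells (Homo sapiens) for inhibition, read by MTT assay, with a stated time of 72 h (a lower number here means a stronger inhibitor, a higher number a weaker inhibitor), compound 1 (`Nc1nc2cc(-c3nn(CCCCC(=O)NO)c4ncnc(N)c34)ccc2o1`) gives 34000 nM and compound 2 (`Nc1nc2cc(-c3nn(CCCCCC(=O)NO)c4ncnc(N)c34)ccc2o1`) gives 21500 nM, which places compound 2 within the scatter of compound 1. Compound 3 (`Nc1nc2cc(-c3nn(CC(=O)NO)c4ncnc(N)c34)ccc2o1`) differs from compound 2 by hydroxycarbamoyl in place of 4-(hydroxycarbamoyl)butyl on a saturated chain carbon bound to an aromatic nitrogen. For the measured compounds named here, the one measured step along this chain, a 1.6-fold lower number from compound 1 to compound 2 (0.20 log units; within the scatter), is small, but it covers a far smaller change, so it offers only a loose guide. The expected step is a 2.0-fold higher number from compound 2 to compound 3 (0.29 log units; within the scatter), toward a higher number. The estimated value for compound 3 is 42000 nM, within a range of 14000 nM to 110000 nM.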

Compound 3, half-maximal inhibitory concentration: 11400 nM
Compound 3: the middle estimate sits 3.7-fold (0.57 log units) above what was measured; measured number below the stated range.
By their numbers in this assay, from the lowest: compounds 3, 2 and 1 (each within the scatter of the next, the first and the last beyond it).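

In this assay, hydroxycarbamoyl in place of 3-(hydroxycarbamoyl)propyl on a saturated chain carbon bound to an aromatic nitrogen gives a 3.0-fold lower number from compound 1 to compound 3 (0.47 log units; beyond the scatter), the only step among these compounds that lies beyond the scatter, and a modest one. Hydroxycarbamoyl in place of 4-(hydroxycarbamoyl)butyl gives a 1.9-fold lower number from compound 2 to compound 3 (0.28 log units; within the scatter), so at this place the longer of these chains brings no gain over the bare hydroxycarbamoyl. Nothing at hand explains these numbers. Still open, from the compounds shown here alone, is how a longer chain would read in this assay, and whether a carboxylic acid or an amine could stand in place of the hydroxycarbamoyl.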